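Swapping the pyrazole substituent on a kinase inhibitor scaffold

The compounds below may be only part of what the source reports. "The series", "measured", "known", "first", "only" and "open" are said of these compounds alone.

Measured compounds:
compound 1 `CC(C)Oc1cc(-c2cncc(-c3cnn(C(C)C)c3)c2)ccc1C(N)=O` with 85 nM
compound 2 `NC(=O)c1ccc(-c2ccc(N)nc2)cc1` with 34000 nM

Of the compounds shown here, two have been measured in an assay on cells for inhibition of MAP kinase-interacting serine/threonine-protein kinase 1 (Homo sapiens), read by mobility shift assay, with stated times of 10 min and 60 min, in the presence of a further agent that is not named here; a higher number here means a weaker inhibitor, a lower number a stronger inhibitor. Compound 1 gives 85 nM, the lowest of the two numbers. Going by the values given here, compound 2 gives 34000 nM, a markedly higher number that lies well beyond the scatter of the method; no single-point step connects these two, since they differ in more than one place, so their values are simply set side by side.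

Compound 3 `Cc1c(-c2cncc(-c3ccc(C(N)=O)c(OC(C)C)c3)c2)cnn1C` is the next compound to be measured in this assay. It differs from compound 1 in a single place: 1,5-dimethyl-1H-pyrazol-4-yl in place of 1-isopropyl-1H-pyrazol-4-yl on an aromatic carbon. Both groups are five-membered aromatic rings carrying two nitrogen atoms and two hydrogen-bond acceptors, so the change is a modest reshaping of one substituent rather than a removal. Among the compounds with values here, with no measured step of this kind available, the expectation is that the step from compound 1 to compound 3 in this assay, a 1.5-fold higher number from compound 1 to compound 3 (0.18 log units; within the scatter), stays within or close to the scatter, leaning if anything toward a slightly weaker inhibitor. Compound 3 is therefore estimated at 130 nM, with a plausible range from 40 nM to 450 nM.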

Compound 3, half-maximal inhibitory concentration: 60 nM
The estimate for compound 3 lay 2.2-fold (0.34 log units) above the measured number; low and high end bracket the measured number.
By their numbers in this assay, from the lowest: compounds 3 and 1 (each within the scatter of the next); then compound 2.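

Replacing 1-isopropyl-1H-pyrazol-4-yl with 1,5-dimethyl-1H-pyrazol-4-yl in this assay gives a 1.4-fold lower number from compound 1 to compound 3 (0.15 log units; within the scatter), so the two compounds stand level. This first single-place comparison shows that, on this aromatic carbon two atoms from the ring nitrogen, the alkyl groups on the pyrazole can differ in this way with no difference that can be told from the scatter, although this rests on one pair alone. No measurement is available that would explain why this pair stands level.

The compounds shown leave open whether the pyrazole itself can be given up at this position, for instance for an amine or a carboxylic acid on the same aromatic carbon, and whether a longer chain such as n-butyl on the pyrazole nitrogen would hold the number in this assay as well. They also leave open what a hydroxyl group in place of the isopropoxy group on the shared core would do.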